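The source may report more compounds than this note shows. Statements on the series, on what has been measured and on what is new or still open speak of the compounds shown alone.

In a functional assay on HepG2 cells (Homo sapiens) for cytotoxicity, read by MTT assay (on this read-out lower numbers stand for stronger inhibition and higher numbers for weaker inhibition), compound 1 (`C=C1C(=O)[C@]23C[C@@]1(Cl)CC[C@H]2[C@@]12C=CC(=O)[C@](C)(C(=O)O1)[C@H]2[C@@H]3C(=O)OC`) gives 39800 nM. Compound 3 (`C=C1C(=O)[C@]23C[C@@]1(F)CC[C@H]2[C@@]12C=CC(=O)[C@](C)(C(=O)O1)[C@H]2[C@@H]3C(=O)OCc1ccccc1`) gives 44100 nM, within the scatter of compound 1, while compound 2 (`C=C1C(=O)[C@]23C[C@@]1(Cl)CC[C@H]2[C@@]12C=CC(=O)[C@](C)(C(=O)O1)[C@H]2[C@@H]3C(=O)OCc1ccccc1`) gives 17900 nM, a lower number than either.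

Compound 4 (`C=C1C(=O)[C@]23C[C@@]1(I)CC[C@H]2[C@@]12C=CC(=O)[C@](C)(C(=O)O1)[C@H]2[C@@H]3C(=O)OC`) has iodo in place of chloro on a saturated ring carbon. Among the measured compounds shown here, the only measured halogen exchange is a 2.5-fold higher number from compound 2 to compound 3 (0.39 log units; beyond the scatter), with fluoro in place of chloro at that same ring carbon. For the measured compounds named here, this modest step was measured with the phenyl present, and no iodo compound has a number yet. The other measured step, a 2.2-fold lower number from compound 1 to compound 2 (0.35 log units; beyond the scatter), is a change elsewhere and bears only on how far the numbers move in this series.

Replacing chloro with iodo is therefore expected to give no step beyond the scatter, with a slight lean towards a lower number. The expected change is a 1.3-fold lower number from compound 1 to compound 4 (0.12 log units; within the scatter). For compound 4 the estimated value is 30000 nM, with an expected range of 13000 nM to 65000 nM.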

Compound 4, half-maximal inhibitory concentration: 87000 nM
Estimate against measurement, compound 4: 2.9-fold (0.46 log units) below; measured number above the stated range.
By their numbers in this assay, from the lowest: compound 2; then compounds 1, 3 and 4 (each within the scatter of the next, the first and the last beyond it).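

In this assay, iodo in place of chloro on this saturated ring carbon gives a step of its own, a 2.2-fold higher number from compound 1 to compound 4 (0.34 log units; beyond the scatter), so the halogen at this position moves the number even without the phenyl. Read with a 2.5-fold higher number from compound 2 to compound 3 (0.39 log units; beyond the scatter), both exchanges away from chloro go towards higher numbers, and in each of these two pairs the chloro compound has the lower number; the fluoro step has the phenyl present and the iodo step does not, so the two steps do not place fluoro and iodo against each other. Nothing available explains why either exchange moves the number in this direction.

The compounds shown leave open whether the iodo step holds with the phenyl present. They also leave open where bromo, or an amine, on this ring carbon would fall relative to chloro.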